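The source may report more compounds than this note shows. Statements on the series, on what has been measured and on what is new or still open speak of the compounds shown alone.

Compound 1, `COc1cc(-c2cc(/C=C/C(=O)c3ccc(Cl)c(Cl)c3)[nH]n2)cc(OC)c1OC`: 19% in a functional assay on KM12 cells (Homo sapiens) for cytotoxicity, read by sulforhodamine B assay, with a stated time of 48 h, tested at 10 uM; on this read-out higher numbers stand for a weaker effect at the one concentration tested and lower numbers for a stronger effect. Compound 2, `COc1ccc(C(=O)/C=C/c2cc(-c3cc(OC)c(OC)c(OC)c3)n[nH]2)cc1OC`: -87% in this assay.

For the measured compounds named here, of the two numbers, compound 2 stands lowest, and the only measured step is the large one, a number 106 percentage points lower from compound 1 to compound 2 (beyond the scatter). Compound 3, `COc1ccc(C(=O)/C=C/c2cc(-c3cc(OC)c(OC)c(OC)c3)n[nH]2)cc1`, differs from compound 2 by hydrogen in place of methoxy on an aromatic carbon. Going by the values given here, no measured step covers this change: the one step on hand swaps the whole dichlorophenyl for dimethoxyphenyl and does not bear on losing a single methoxy. Compound 3 is therefore expected near -55% in this assay, within -100% to 15%. That expectation amounts to a number 32 percentage points higher from compound 2 to compound 3 (beyond the scatter), a guess resting on compound 2 alone.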

Compound 3, a percentage reported as activity, at one concentration (the size of the read-out at that concentration, not a potency): -88%
The estimate for compound 3 lay 33 percentage points above the measured number; measured number inside the range.
By their numbers in this assay, from the lowest: compounds 3 and 2 (each within the scatter of the next); then compound 1.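

Going from 3,4-dimethoxyphenyl to 4-methoxyphenyl gives a number 1 percentage points lower from compound 2 to compound 3 (within the scatter) in this assay, so the methoxy ortho to a methoxy group can be replaced by hydrogen without a change beyond the scatter. For the compounds shown here, with only the one methoxy left, the 4-methoxyphenyl still gives a number 107 percentage points lower from compound 1 to compound 3 (beyond the scatter), a large step from the 3,4-dichlorophenyl. Nothing available explains why this methoxy can be lost without a change beyond the scatter.

It remains open whether the remaining methoxy matters, since no phenyl without one is shown. Also open, as far as these compounds go, is how an amine or a longer ethoxy chain would read at the same place.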